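Replacing the ortho methyl on the silicon-bound ring

The source may report more compounds than this note shows. Statements on the series, on what has been measured and on what is new or still open speak of the compounds shown alone.

Measured so far in a functional assay on liver (Sus scrofa) for inhibition of squalene monooxygenase (Homo sapiens), using microsomes; on this read-out lower numbers stand for stronger inhibition and higher numbers for weaker inhibition:
compound 1, `CCN(C/C=C/C#CC(C)(C)C)Cc1cccc(OC[Si](C)(C)c2ccccc2C)c1`, gives 30 nM
compound 2, `CCN(C/C=C/C#CC(C)(C)C)Cc1cccc(OC[Si](C)(C)c2ccc(C(N)=O)cc2)c1`, gives 5000 nM
compound 3, `CCN(C/C=C/C#CC(C)(C)C)Cc1cccc(OC[Si](C)(C)c2ccc(C=O)cc2)c1`, gives 100 nM

Compound 1 gives the lowest of the three numbers; compound 3 sits nearest, with a 3.3-fold higher number from compound 1 to compound 3 (0.52 log units; beyond the scatter), and compound 2 furthest, with a 170-fold higher number from compound 1 to compound 2 (2.22 log units; beyond the scatter). Compound 4, `CCN(C/C=C/C#CC(C)(C)C)Cc1cccc(OC[Si](C)(C)c2ccccc2-c2ccsc2)c1`, differs from compound 1 by thiophen-3-yl in place of methyl on an aromatic carbon. Among the compounds with values here, no measured step alters this position: the known steps change the 4-position of the same ring, and from compound 2 to compound 3 the step of a 50-fold lower number from compound 2 to compound 3 (1.70 log units; beyond the scatter) concerns only that substituent. Both measured departures from compound 1 raised the number, so a modest rise is expected, a 2.7-fold higher number from compound 1 to compound 4 (0.43 log units; beyond the scatter), and compound 4 is estimated at 80 nM, likely between 25 nM and 300 nM.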

Compound 4, half-maximal inhibitory concentration: 10000 nM
Compound 4: the middle estimate sits 130-fold (2.10 log units) below what was measured, and the stated range ends below it.
By their numbers in this assay, from the lowest: compound 1; then compound 3; then compounds 2 and 4 (each within the scatter of the next).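

The aromatic carbon ortho to a large group turns out not to accept every replacement of its methyl: in this assay, thiophen-3-yl there brings a large loss (a 330-fold higher number from compound 1 to compound 4 (2.52 log units; beyond the scatter)). The resulting 2-(thiophen-3-yl)phenyl also does far worse than 4-formylphenyl (a 100-fold higher number from compound 3 to compound 4 (2.00 log units; beyond the scatter)) and cannot be told apart from 4-carbamoylphenyl (a 2.0-fold higher number from compound 2 to compound 4 (0.30 log units; within the scatter)), a gap within the scatter. Nothing available accounts for this loss. Going by these compounds, whether an ethyl, a methoxy or a chlorine on this carbon would keep the number close to that of the methyl remains open.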